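The source may hold more compounds than are shown below. What is called first, only, known or untested is meant among the compounds shown, and "the series" means these compounds.

Compound 2 `O=C1C[C@H](OCc2cn(-c3cccc(Cl)c3Cl)nn2)[C@H]2CO[C@@H]1O2` gives 26000 nM in a functional assay on MDA-MB-231 cells (Homo sapiens) for cytotoxicity, read by MTT assay, with a stated time of 48 h (a higher number here means a weaker inhibitor, a lower number a stronger inhibitor), the highest of the two numbers measured, yet its step from compound 1 `COC(=O)Cn1cc(CO[C@H]2CC(=O)[C@@H]3OC[C@H]2O3)nn1`, which gives 21300 nM, is a 1.2-fold higher number from compound 1 to compound 2 (0.09 log units; within the scatter). Compound 3 `O=C1C[C@H](OCc2cn(C3CCCCC3)nn2)[C@H]2CO[C@@H]1O2` carries a different group at that same aromatic nitrogen: cyclohexyl in place of 2,3-dichlorophenyl on an aromatic nitrogen. Going by the values given here, the only measured step at this position, which swapped a (methoxycarbonyl)methyl for a 2,3-dichlorophenyl, stayed within the scatter, so a similarly small step, a 1.0-fold lower number from compound 2 to compound 3 (0.02 log units; within the scatter), is expected in this assay. Compound 3 is therefore estimated at 25000 nM, with a range from 8000 nM to 70000 nM.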

Compound 3, half-maximal inhibitory concentration: 24300 nM
For compound 3 the middle estimate is 1.0-fold (0.01 log units) above the measured one; low and high end bracket the measured number.
By their numbers in this assay, from the lowest: compounds 1, 3 and 2 (each within the scatter of the next).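

In this assay cyclohexyl in place of 2,3-dichlorophenyl gives a 1.1-fold lower number from compound 2 to compound 3 (0.03 log units; within the scatter) and cyclohexyl in place of (methoxycarbonyl)methyl gives a 1.1-fold higher number from compound 1 to compound 3 (0.06 log units; within the scatter) on the same aromatic nitrogen. Across these three compounds, a non-aromatic carbon ring therefore reads the same as an aromatic ring carrying two chlorines, and the same as the ester-bearing chain. No measurement shown here explains this sameness.
Still open, on these data alone, is whether a group of another kind on this nitrogen, such as an amine or a carboxylic acid, would move the number beyond the scatter.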